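The compounds below may be only part of what the source reports. "The series", "measured", "known", "first", "only" and "open" are said of these compounds alone.

Within the data shown here, in a functional assay on HepG2 cells (Homo sapiens) for antiproliferative activity, read by MTT assay (on this read-out lower numbers stand for stronger inhibition and higher numbers for weaker inhibition), three compounds on a shared core have numbers so far. Compound 2 `N#Cc1c(F)c(F)c(C(C(=O)c2ccccc2)=C2NCCN2)c(C#N)c1F` gives 9.1 ug/mL as the lowest of the three, while compound 1 `N#Cc1c(F)c(Cl)c(C(C(=O)c2ccccc2)=C2NCCN2)c(C#N)c1F` gives 32.6 ug/mL and compound 3 `N#Cc1c(F)c(C#N)c(C(C(=O)c2ccccc2)=C2NCCN2)c(F)c1Nc1ccccc1` gives 102 ug/mL on the same read-out. Compound 4 `N#Cc1c(F)c(F)c(C(C(=O)c2ccc(Cl)cc2)=C2NCCN2)c(C#N)c1F` departs from compound 2 only on the benzoyl group, which becomes (4-chlorophenyl)carbonyl: chloro in place of hydrogen on an aromatic carbon, para to a large group (chloro in place of hydrogen on an aromatic carbon). Among the measured compounds shown here, two measured steps bear on this, and neither touches the phenyl ring. The modest one (a 3.6-fold lower number from compound 1 to compound 2 (0.55 log units; beyond the scatter)) puts fluoro in place of chloro elsewhere in the molecule, and the large one (an 11-fold higher number from compound 2 to compound 3 (1.05 log units; beyond the scatter)) puts anilino in place of fluoro there. Neither carries over directly, so only a small step is expected in this assay with a slight lean upward, given the higher number of chloro-bearing compound 1 (a 3.6-fold lower number from compound 1 to compound 2 (0.55 log units; beyond the scatter)) in that pair. The estimated step (a 1.2-fold higher number from compound 2 to compound 4 (0.08 log units; within the scatter)) is not expected to pass the scatter. For compound 4 the expected value is 11 ug/mL within an estimated range of 4 ug/mL to 30 ug/mL for repeat measurements.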

Compound 4, half-maximal inhibitory concentration: 12.5 ug/mL
Beside the measured number, compound 4's estimate is 1.1-fold (0.06 log units) below it; the measured number falls inside the stated range.
By their numbers in this assay, from the lowest: compounds 2 and 4 (each within the scatter of the next); then compound 1; then compound 3.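

Among these compounds, the phenyl ring of the benzoyl group is varied here for the first time, and in this assay chloro in place of hydrogen at the position para to a large group gives a 1.4-fold higher number from compound 2 to compound 4 (0.14 log units; within the scatter), so compound 2 and compound 4 cannot be told apart on this read-out. The earlier steps shown here, made elsewhere in the molecule, were beyond the scatter, among them a 3.6-fold lower number from compound 1 to compound 2 (0.55 log units; beyond the scatter), so a chloro group does not carry the same weight in every place on this scaffold. Nothing at hand gives a reason for this result.

The compounds shown leave open whether this position would tolerate a larger or very different group, such as a methoxy group, an amine or a carboxylic acid. They also leave open whether chloro on the other carbons of this phenyl ring would stay within the scatter of compound 2.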